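A Larger Ester Group on Compound 3

This account rests on a few compounds, and the source may have more. Where it says the series, first, only, none or still open, it means among the compounds named here.

In a functional assay on the whole organism with Scenedesmus acutus as the target, with a stated time of 20 h (on this read-out higher numbers stand for weaker inhibition and lower numbers for stronger inhibition), compound 1 `O=C(O)c1cc(N2C(=O)C3=C(CCCC3)C2=O)ccc1Cl` gives only a limit, > 100000 nM, and not a number. Going by the values given here, compound 2 `COC(=O)c1cc(N2C(=O)C3=C(CCCC3)C2=O)ccc1Cl` reads 1620 nM, and compound 3 `COC(=O)c1cc(N2C(=O)C3=C(CCCC3)C2=O)c(F)cc1Cl` reads 170 nM, the lowest number so far.

Compound 4 `CCC(C)OC(=O)c1cc(N2C(=O)C3=C(CCCC3)C2=O)c(F)cc1Cl` alters compound 3 in one place: sec-butyl in place of methyl on an oxygen next to a carbonyl group. Sec-butyl stands in place of methyl on an oxygen next to a carbonyl group.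

The most relevant evidence comes from that same oxygen. There, an at least 61-fold lower number from compound 1 to compound 2 (1.79 log units; beyond the scatter), a large step made by methyl replacing hydrogen. Among the compounds with values here, the number can therefore move a great deal at this place, but no measured compound carries a chain longer than methyl there. The other measured change, a 9.5-fold lower number from compound 2 to compound 3 (0.98 log units; beyond the scatter), is a modest step made by fluoro replacing hydrogen on an aromatic carbon, and it says little about this swap.

A small step with no firm direction is therefore expected, and the estimate is a 1.1-fold lower number from compound 3 to compound 4 (0.05 log units; within the scatter). For compound 4, the estimated value is 150 nM, with an expected range of 40 nM to 600 nM.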

Compound 4, half-maximal inhibitory concentration: 74.1 nM
Estimate against measurement, compound 4: 2.0-fold (0.31 log units) above; low and high end bracket the measured number.
By their numbers in this assay, from the lowest: compound 4; then compound 3; then compound 2. At a limit, above all of these: compound 1.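

Replacing methyl with sec-butyl gives, in this assay, a 2.3-fold lower number from compound 3 to compound 4 (0.36 log units; beyond the scatter), a modest step. Until now this oxygen had only shown methyl against hydrogen, so this is the first sign that a group larger than methyl can sit there and still lower the number, at least on the fluoro-bearing compound 3. The earlier step at this oxygen has no exact size, since compound 1 gives only a limit: the limit of > 100000 nM in this assay, at which 1 of the 4 values shown sits.

With sec-butyl the only larger group shown, chain length and branching cannot be told apart, and an ethyl, isopropyl or straight butyl group would be needed to separate them. From the compounds shown here alone, it also stays open whether sec-butyl would lower the number in the same way on compound 2, which has hydrogen in place of the fluoro.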